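The compounds below may be only part of what the source reports. "The series", "measured", "known", "first", "only" and "open" are said of these compounds alone.

Measured so far in a functional assay on HepG2 cells (Homo sapiens) for antiproliferative activity, read by MTT assay, with a stated time of 72 h; a lower number here means a stronger inhibitor, a higher number a weaker inhibitor:

Compound 1 `O=C1O/C(=C\Cn2cc(-c3cc(F)cc(F)c3)nn2)C(OCc2ccccc2)=C1OCc1ccccc1` gives > 100000 nM, which is a limit of the assay rather than a number.
Compound 2 `O=C1O[C@H]([C@@H](O)Cn2cc(-c3cccc(O)c3)nn2)C(OCc2ccccc2)=C1OCc1ccccc1` gives 62700 nM.
Compound 3 `CCCCc1cn(C[C@H](O)[C@H]2OC(=O)C(OCc3ccccc3)=C2OCc2ccccc2)nn1` gives 32800 nM.

Compound 3 holds the lower of the two real numbers, with compound 2 nearest: a 1.9-fold lower number from compound 2 to compound 3 (0.28 log units; within the scatter). Compound 1 sits only at the limit of > 100000 nM in this assay, at which 1 of the 3 values shown sits. Compound 4 `COc1ccccc1-c1cn(C[C@H](O)[C@H]2OC(=O)C(OCc3ccccc3)=C2OCc2ccccc2)nn1` differs from compound 3 in one place: 2-methoxyphenyl in place of butyl on an aromatic carbon. Among the measured compounds shown here, the one measured step that bears on this, from compound 2 to compound 3, exchanged an aromatic group for butyl and stayed within the scatter, so putting a different aromatic group back on the same carbon is expected to leave this assay much as it is, and a 1.4-fold higher number from compound 3 to compound 4 (0.14 log units; within the scatter) is expected to stay within the scatter. Compound 4 is therefore estimated at 45000 nM, within 15000 nM to 100000 nM.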

Compound 4, half-maximal inhibitory concentration: > 100000 nM
Compound 4 ended at the assay's limit (the forecaster's own chance of this, stated with the estimate: 25%); middle value at least 2.2-fold (0.34 log units) away from the limit.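

In this assay, this aromatic carbon proves sensitive to the group it carries: 2-methoxyphenyl in place of butyl gives an at least 3.0-fold higher number from compound 3 to compound 4 (0.48 log units; beyond the scatter). Compound 4 has a limit of the assay rather than a real number, a place it shares with one other compound: the limit of > 100000 nM in this assay, at which 2 of the 4 values shown sit. The two aromatic groups cannot be ranked, as their comparison gives only an at least 1.5-fold higher number from compound 2 to compound 4 (0.20 log units; that floor lies within the scatter).

The compounds shown leave open whether a longer chain or an amine on this carbon would give a lower number than butyl. On these data alone, the real number of compound 4 also stays unknown.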